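The source may report more compounds than this note shows. Statements on the series, on what has been measured and on what is new or still open speak of the compounds shown alone.

Measured compounds:
Compound 1 `CC(/C=N/Nc1ccc([N+](=O)[O-])cc1)=N\NC(=O)c1ccccc1Nc1ccccc1`: in an ADME assay on J774 cells (Mus musculus, strain BALB/c) for cytotoxicity, read by resazurin assay, with a stated time of 72 h (on this read-out lower numbers stand for higher toxicity in this test and higher numbers for lower toxicity in this test), compound 1 reaches only a limit, > 100000 nM.
Compound 2 `CC(/C=N/Nc1ccc([N+](=O)[O-])cc1)=N\NC(=O)c1ccc(O)cc1`: in this assay compound 2 gives 51000 nM.
Compound 3 `CC(/C=N/N(C)c1ccc([N+](=O)[O-])cc1)=N\NC(=O)c1cc([N+](=O)[O-])cc([N+](=O)[O-])c1`: in this assay compound 3 gives 39000 nM.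

Going by the values given here, only two of the three values are real numbers. Compound 2 stands at the top of those two, but the gap to compound 3 is within the usual scatter of this kind of measurement, so the two cannot be told apart. The third value, that of compound 1, is the limit of > 100000 nM in this assay, at which 1 of the 3 values shown sits, so it says only that its toxicity is too weak to be measured, not where it lies. All three measured compounds therefore sit in a region of weak cytotoxicity.

Compound 4 `COc1ccc(C(=O)N/N=C(C)/C=N/Nc2ccc([N+](=O)[O-])cc2)cc1` differs from compound 2 in one place: methyl in place of hydrogen on an oxygen on an aromatic ring. Among the compounds with values here, no pair of measured compounds differs in exactly this way, so there is no measured step to lean on.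

With so little to go on, the expectation is that the step of a 1.2-fold higher number from compound 2 to compound 4 (0.07 log units; within the scatter) is none beyond the scatter. Compound 4 is accordingly expected to give about 60000 nM, with a range from 25000 nM to 150000 nM.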

Compound 4, half-maximal cytotoxic concentration: > 100000 nM
Compound 4: only a limit was reported (the forecaster's own chance of this, stated with the estimate: 30%); middle value at least 1.6-fold (0.22 log units) away from the limit.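

Going by these compounds alone, replacing hydroxy with methoxy on the 4-hydroxyphenyl group gives the only measured step at this position: in this assay there is an at least 1.9-fold higher number from compound 2 to compound 4 (0.29 log units; that floor lies within the scatter). Compound 4 reports only a limit, so this step is a floor and not a size; the true change could be small or much larger, and the floor alone does not separate it from the scatter. What the result does show is that putting methyl on this oxygen brought no measurable gain in toxicity in this test, and that compound 4 now shares the top of the range with compound 1: the limit of > 100000 nM in this assay, at which 2 of the 4 values shown sit.

The compounds shown leave open how large the difference between compound 2 and compound 4 really is, since a limit cannot give that, and whether the same change would read the same way on a compound whose values are not so close to the limit. They also do not tell what an amine or a carboxylic acid in place of the hydroxy group, or a longer chain such as ethyl on the same oxygen, would do to the number.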